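The compounds below may be only part of what the source reports. "The series", "measured", "known", "first", "only" and "open" are said of these compounds alone.

Measured in a functional assay on aorta (Rattus norvegicus, strain Sprague-Dawley) for inhibition; on this read-out lower numbers stand for an effect already at smaller amounts and higher numbers for an effect only at larger amounts of compound:
compound 1 `C[C@H]1CO[C@]2(C)Oc3c(c4c(c5c3C[C@@H]3[C@@H](C)CO[C@]3(C)O5)C[C@@H]3[C@@H](C)CO[C@]3(C)O4)C[C@H]12` gives 31000 nM;
compound 2 `CCCOc1cc2c(c3c1C[C@@H]1[C@@H](C)CO[C@]1(C)O3)C[C@@H]1[C@@H](C)CO[C@]1(C)O2` gives 77000 nM;
compound 3 `Cc1cc2c(c3c1C[C@@H]1[C@@H](C)CO[C@]1(C)O3)C[C@@H]1[C@@H](C)CO[C@]1(C)O2` gives 52000 nM.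

Compound 3 stands second highest of the three numbers; its nearest neighbour is compound 2, and compound 1 lies furthest, both within the scatter of compound 3. Compound 4 `C#CCOc1cc2c(c3c1C[C@@H]1[C@@H](C)CO[C@]1(C)O3)C[C@@H]1[C@@H](C)CO[C@]1(C)O2` has not yet been measured. It differs from compound 3 in one place: propargyloxy in place of methyl on an aromatic carbon. Among the compounds with values here, the only measured step that bears on this change is the one from propoxy to methyl on the same aromatic carbon, a 1.5-fold lower number from compound 2 to compound 3 (0.17 log units; within the scatter). Replacing methyl with an alkoxy chain therefore gave no shift beyond the scatter, and for compound 4 the step of a 1.3-fold higher number from compound 3 to compound 4 (0.13 log units; within the scatter) is expected to stay within the scatter as well. Compound 4 is estimated at 70000 nM, in a range from 35000 nM to 140000 nM.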

Compound 4, half-maximal effective concentration: 22000 nM
Compound 4: middle estimate off by 3.2-fold (0.50 log units), on the high side; the whole stated range lies above it.
By their numbers in this assay, from the lowest: compounds 4, 1, 3 and 2 (each within the scatter of the next, the first and the last beyond it).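

In this assay this aromatic carbon now shows a shift beyond the scatter, with a 2.4-fold lower number from compound 3 to compound 4 (0.37 log units; beyond the scatter) on putting propargyloxy in place of methyl, which the earlier step from propoxy to methyl did not show. An oxygen-linked chain alone therefore does not fix the number here, as a 3.5-fold lower number from compound 2 to compound 4 (0.54 log units; beyond the scatter) separates ethynyl from ethyl on that chain. No measurement shown gives a reason for either step. On these data alone, what remains open is whether a longer chain ending in a triple bond would follow compound 4. An amine or a carboxylic acid on this chain is equally untested in the compounds shown.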